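Enlarging the Alkoxy Group on a Shared Core

This account rests on a few compounds, and the source may have more. Where it says the series, first, only, none or still open, it means among the compounds named here.

Compound 1 `CCOc1cc(CCc2nc(C)c(CC)s2)nc(NCc2cc(Cl)cc(NC(=O)OC(C)C)c2)c1` gives 33 nM in an assay on cells for binding affinity to Neuropeptide Y receptor type 1 (Homo sapiens); a higher number here means a weaker inhibitor, a lower number a stronger inhibitor.
Compound 2 `CCc1sc(CCc2cc(OC(C)C)cc(NCc3cc(Cl)cc(NC(=O)OC(C)C)c3)n2)nc1C` gives 12 nM in this assay.
Compound 3 `CCc1sc(CCc2cc(OC(CC)CC)cc(NCc3cc(Cl)cc(NC(=O)OC(C)C)c3)n2)nc1C` gives 5.5 nM in this assay.

Among these three numbers, compound 2 stands second highest: the step of a 2.8-fold lower number from compound 1 to compound 2 (0.44 log units; beyond the scatter) led to it, and the step of a 2.2-fold lower number from compound 2 to compound 3 (0.34 log units; beyond the scatter) went beyond it. Compound 4 `CCc1sc(CCc2cc(OCCc3ccccc3)cc(NCc3cc(Cl)cc(NC(=O)OC(C)C)c3)n2)nc1C` differs from compound 2 as follows: phenethyl in place of isopropyl on an oxygen on an aromatic ring. For the measured compounds named here, the steps that bear on this all enlarged the group on the oxygen on the aromatic ring, and each lowered the number: a 2.8-fold lower number from compound 1 to compound 2 (0.44 log units; beyond the scatter), a 2.2-fold lower number from compound 2 to compound 3 (0.34 log units; beyond the scatter) and a 6.0-fold lower number from compound 1 to compound 3 (0.78 log units; beyond the scatter). Phenethyl is larger again and brings an aromatic ring that no measured compound carries there, so the pattern is only a guide. A modest lowering is expected, a 2.0-fold lower number from compound 2 to compound 4 (0.30 log units; within the scatter). Compound 4 is estimated at 6 nM, within 2 nM to 25 nM.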

Compound 4, half-maximal inhibitory concentration: 30 nM
For compound 4 the middle estimate is 5.0-fold (0.70 log units) below the measured one; measured number above the stated range.
By their numbers in this assay, from the lowest: compound 3; then compound 2; then compounds 4 and 1 (each within the scatter of the next).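

Enlarging the group on this oxygen does not always lower the number: with phenethyl the trend reverses, giving a 2.5-fold higher number from compound 2 to compound 4 (0.40 log units; beyond the scatter) and a 5.5-fold higher number from compound 3 to compound 4 (0.74 log units; beyond the scatter). Set against ethyl, the larger phenethyl group brings no clear gain, with a 1.1-fold lower number from compound 1 to compound 4 (0.04 log units; within the scatter). Nothing measured here explains this reversal. As far as these compounds go, whether it comes from the aromatic ring or from the chain length stays open. A benzyl or a plain butyl group on the same oxygen could help separate the two, while a cyclopentyl group could show how far branched groups can go.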